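The compounds below may be only part of what the source reports. "The series", "measured", "known", "first", "only" and "open" are said of these compounds alone.

Measured in an assay on isolated protein for inhibition of aldehyde dehydrogenase 1A1 (Homo sapiens), read by spectrophotometry, tested at 10 uM; on this read-out higher numbers stand for more inhibition at the one concentration tested (going by the name of the read-out) and lower numbers for less inhibition:

Compound 1 `Cc1cccc(Cn2c(CN3CCN(C(=O)c4ccc([N+](=O)[O-])cc4)CC3)nc3ccccc32)c1` gives 24.3%
Compound 2 `Cc1cccc(Cn2c(OC3CCN(C(=O)c4ccco4)CC3)nc3ccccc32)c1` gives 68.3%

Of the compounds shown here, two have been measured so far, and compound 1 stands at the lower of the two numbers. Compound 2 reads a good deal higher, and the gap between these two values is beyond the usual scatter of this kind of measurement. Within the data shown here, the two compounds differ in more than one place, so the two values show only that compound 2 inhibits more at the tested concentration, and nothing can be traced to a single change.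

Compound 3 `Cc1cccc(Cn2c(CN3CCN(C(=O)c4ccc(C#N)cc4)CC3)nc3ccccc32)c1` is not yet measured. It differs from compound 1 in a single place: cyano in place of nitro on an aromatic carbon. Everything else in the molecule is kept as it is in compound 1.

Among the measured compounds shown here, no measured pair shows what this kind of exchange does in this assay, so there is no directly comparable step to lean on. On that basis compound 3 is expected to stay close to compound 1, with a step of a number 2.7 percentage points higher from compound 1 to compound 3 (within the scatter) that is expected to fall within the scatter rather than beyond it. For compound 3 the estimated value is 27%, with a likely range from 8% to 50%.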

Compound 3, a percentage reported as inhibition, at one concentration (the size of the read-out at that concentration, not a potency): 20.8%
Compound 3: the middle estimate sits 6.2 percentage points above what was measured; the measured number falls inside the stated range.
By their numbers in this assay, from the lowest: compounds 3 and 1 (each within the scatter of the next); then compound 2.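

In this assay, exchanging nitro for cyano on an aromatic carbon para to a large group gives a step of a number 3.5 percentage points lower from compound 1 to compound 3 (within the scatter). Among these compounds, this is the first comparison here in which only one place in the molecule differs, so, unlike the earlier gap between two compounds that differ in several places, it can be traced to one exchange. At this position, the read-out does not separate the two groups, even though the exchange replaces 3 heavy atoms and 2 hydrogen-bond acceptors with 2 heavy atoms and 1 hydrogen-bond acceptor; nothing at hand bears on why the two groups read alike.

The compounds shown leave open whether this position responds to any exchange at all, since nitro and cyano are the only two groups seen there, and a plain hydrogen, an amine, a carboxylic acid or a methoxy group could read quite differently. They also leave open whether the same exchange would give a similarly small step with the group attached elsewhere on the ring or on a different core.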